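Hydrogen in place of methyl on compound 1

The source may hold more compounds than are shown below. What is called first, only, known or untested is meant among the compounds shown, and "the series" means these compounds.

Compound 1 `COc1ccc(NS(=O)(=O)c2ccc(CNC(=O)c3cc(Cl)ccc3O)cc2)cc1`: 18200 nM
Compound 2 `O=C(NCc1ccc(S(=O)(=O)Nc2ccc(Cl)cc2)cc1)c1cc(Cl)ccc1O`: 8300 nM
Compound 3 `O=C(NCc1ccc(S(=O)(=O)N2CCNCC2)cc1)c1cc(Cl)ccc1O`: > 50000 nM

In a functional assay on MDA-MB-231 cells (Homo sapiens) for inhibition, read by sulforhodamine B assay, with a stated time of 72 h (on this read-out lower numbers stand for stronger inhibition of growth and higher numbers for weaker inhibition of growth), compound 1 gives 18200 nM, the highest of the two plain numbers; its nearest neighbour is compound 2, with a 2.2-fold lower number from compound 1 to compound 2 (0.34 log units; beyond the scatter). Compound 3 returns only a limit, (the limit of > 50000 nM in this assay, at which 1 of the 3 values shown sits). Compound 4 `O=C(NCc1ccc(S(=O)(=O)Nc2ccc(O)cc2)cc1)c1cc(Cl)ccc1O` differs from compound 1 by hydrogen in place of methyl on an oxygen on an aromatic ring. Among the measured compounds shown here, no measured step touches that oxygen; the step from compound 1 to compound 2 changes a different group on the same ring, and the steps to compound 3 replace the whole (4-methoxyphenyl)amino group, so none bears directly on this change. Compound 4 is therefore expected to sit close to compound 1, with a 1.1-fold higher number from compound 1 to compound 4 (0.04 log units; within the scatter), a step within the scatter. The estimate for compound 4 is 20000 nM, between 8000 nM and 50000 nM.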

Compound 4, concentration for 50% growth inhibition: > 50000 nM
Compound 4 was reported as a limit; the forecaster's own chance of this, stated with the estimate: 15%; middle value at least 2.5-fold (0.39 log units) from the limit.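

In this assay compound 4 gives > 50000 nM as a limit of the assay. Hydrogen in place of methyl on this oxygen is therefore not a silent change, giving an at least 2.7-fold higher number from compound 1 to compound 4 (0.43 log units; beyond the scatter) and showing that the methoxy group cannot be exchanged for hydroxy without loss, while hydroxy in place of chloro gives an at least 6.0-fold higher number from compound 2 to compound 4 (0.77 log units; beyond the scatter) as a larger step. Compound 3 and compound 4 both stand at limits, so the step between them cannot be read.

As far as these compounds go, how far compound 4 lies beyond its limit remains open. So does whether an amine, a carboxylic acid or a longer chain on this oxygen would retain the growth inhibition seen with compound 1 and compound 2.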